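Replacing the 2,4,6-Trihydroxyphenyl Group of Compound 3

This account rests on a few compounds, and the source may have more. Where it says the series, first, only, none or still open, it means among the compounds named here.

In a functional assay on DU-145 cells (Homo sapiens) for inhibition, read by trypan blue exclusion, with a stated time of 96 h (a higher number here means a weaker inhibitor of growth, a lower number a stronger inhibitor of growth), compound 1 `Cc1ccc(CS/C(=C/c2c(O)cc(O)cc2O)C(=O)c2ccc(Cl)cc2)cc1` gives 50000 nM, compound 2 `O=C(/C(=C\c1c(O)cc(O)cc1O)S(=O)(=O)c1ccccc1Br)c1ccc(Cl)cc1` gives 50000 nM and compound 3 `O=C(/C(=C\c1c(O)cc(O)cc1O)SCc1ccc(Cl)c(Cl)c1)c1ccc(Cl)cc1` gives 25000 nM. Compound 3 cannot be separated from the other two, since a 2.0-fold lower number from compound 1 to compound 3 (0.30 log units; within the scatter) and a 2.0-fold lower number from compound 2 to compound 3 (0.30 log units; within the scatter) both lie within the scatter, as does no change at the digits printed from compound 1 to compound 2 (within the scatter).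

Compound 4 `CN(C)c1ccc(/C=C(/SCc2ccc(Cl)c(Cl)c2)C(=O)c2ccc(Cl)cc2)cc1` has 4-(dimethylamino)phenyl in place of 2,4,6-trihydroxyphenyl on a double-bonded chain carbon bound to a double-bonded chain carbon. All three measured steps alter a different part of the molecule, so none tests this swap directly. With no guide to its size, no step beyond the scatter is expected, though with wide uncertainty. The estimated step runs a 1.3-fold lower number from compound 3 to compound 4 (0.10 log units; within the scatter). For compound 4 the expected value is 20000 nM, with an estimated range of 4000 nM to 60000 nM.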

Compound 4, concentration for 50% growth inhibition: 50000 nM
Estimate against measurement, compound 4: 2.5-fold (0.40 log units) below; the measured number falls inside the stated range.
By their numbers in this assay, from the lowest: compounds 3, 1, 2 and 4 (each within the scatter of the next).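

Among these compounds, this step is the first test of the group on the double-bonded chain carbon: in this assay, 4-(dimethylamino)phenyl in place of 2,4,6-trihydroxyphenyl gives a 2.0-fold higher number from compound 3 to compound 4 (0.30 log units; within the scatter). Hydrogen-bond donors on this group fall from 3 to 0, yet the two compounds cannot be separated in this assay. No measurement shown offers an explanation for this result.

As far as these compounds go, it remains open whether a plain phenyl, or a phenyl carrying a carboxylic acid, at this place would move the number beyond the scatter.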